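Replacing a chlorohydrin side chain with a ketone on the shared core

This account rests on a few compounds, and the source may have more. Where it says the series, first, only, none or still open, it means among the compounds named here.

Of the compounds shown here, two of one series have been measured in a functional assay; a lower number here means a stronger inhibitor, a higher number a weaker inhibitor. Compound 1 `C=CC(C)(C)c1[nH]c2ccc(C[C@@H](O)C(C)(C)Cl)cc2c1/C=C1\NC(=O)[C@H](C)NC1=O` gives 79000 nM and stands highest of the two numbers, although its nearest neighbour, compound 2 `C=CC(C)(C)c1[nH]c2ccc(C[C@@H](O)C(=C)C)cc2c1/C=C1\NC(=O)[C@H](C)NC1=O`, gives 75000 nM, and the step of a 1.1-fold lower number from compound 1 to compound 2 (0.02 log units; within the scatter) is within the scatter. Compound 3 `C=CC(C)(C)c1[nH]c2ccc(CC(=O)C(C)C)cc2c1/C=C1\NC(=O)[C@H](C)NC1=O` has not yet been measured. It differs from compound 1 as follows: isopropylcarbonyl in place of 2-chloro-1-hydroxy-2-methylpropyl on a saturated chain carbon bound to an aromatic carbon. Going by the values given here, the only measured step alters a different part of the same side chain, and it lies within the scatter, so no measured step speaks directly to this change. Because the step of a 1.1-fold lower number from compound 1 to compound 2 (0.02 log units; within the scatter) showed no movement when that chain was varied, the expectation is that compound 3 also falls within the scatter of compound 1 in this assay, an expected step of a 1.0-fold higher number from compound 1 to compound 3 (0.01 log units; within the scatter). Compound 3 is therefore estimated at 80000 nM, with a range from 30000 nM to 200000 nM.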

Compound 3, half-maximal inhibitory concentration: 79000 nM
Estimate against measurement, compound 3: 1.0-fold (0.01 log units) above; low and high end bracket the measured number.
By their numbers in this assay, from the lowest: compounds 2, 1 and 3 (each within the scatter of the next).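

In this assay the change reads no change at the digits printed from compound 1 to compound 3 (within the scatter) and it removes the chlorine, the hydrogen-bond donor and the defined stereocentre of the 2-chloro-1-hydroxy-2-methylpropyl group in a single step, whereas compounds 1 and 2 both keep the hydroxyl group and that stereocentre. The second new step, with isopropylcarbonyl in place of 1-hydroxy-2-methylprop-2-en-1-yl, reads a 1.1-fold higher number from compound 2 to compound 3 (0.02 log units; within the scatter) and also stays within the scatter, so among these three compounds neither the hydroxyl group nor the stereocentre is needed to hold the number where it stands. Nothing measured here offers an explanation for this result.

The compounds shown leave open whether any group on this saturated chain carbon bound to an aromatic carbon can shift the number, for instance an amine or a carboxylic acid in place of isopropylcarbonyl. They also leave open what changes elsewhere on the shared core would do.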